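A few compounds are considered here, and "the series" means these few. Any claim that something is new, unique, unknown or untested is made for them only; others in the source may bear on it.

In a functional assay on MCF7 cells (Homo sapiens) for cytotoxicity, read by sulforhodamine B assay, with a stated time of 48 h (a lower number here means a stronger inhibitor, a higher number a weaker inhibitor), compound 1 (`O=C(c1cccnc1)c1ccccc1O`) gives 24600 nM and compound 2 (`O=C(c1cccnc1)c1cc(Cl)cc(Cl)c1O`) gives 29600 nM so that the two values lie within the usual scatter of each other. Compound 3 (`O=C(c1cccnc1)c1cc(Cl)ccc1O`) is not yet measured and differs from compound 2 by hydrogen in place of chloro on an aromatic carbon. Going by the values given here, no measured step covers this change. Since compound 2 at 29600 nM lies within the scatter of compound 1 at 24600 nM no step beyond the scatter is expected in this assay here. The expected 1.1-fold lower number from compound 2 to compound 3 (0.04 log units; within the scatter) is accordingly small. For compound 3 the estimate is 27000 nM with an expected range from 14000 nM to 50000 nM in this series.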

Compound 3, half-maximal inhibitory concentration: 29000 nM
Beside the measured number, compound 3's estimate is 1.1-fold (0.03 log units) below it; the range from low to high includes it.
By their numbers in this assay, from the lowest: compounds 1, 3 and 2 (each within the scatter of the next).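

In this assay, hydrogen in place of the chloro ortho to a hydroxy group gives a 1.0-fold lower number from compound 2 to compound 3 (0.01 log units; within the scatter), so this chloro makes no readable difference when the other chloro stays in place. Chloro in place of hydrogen on the core of compound 1 gives a 1.2-fold higher number from compound 1 to compound 3 (0.07 log units; within the scatter), so the remaining chloro, on its own, also shows no step beyond the scatter. No evidence accompanies these steps to account for them.

From the compounds shown here alone, whether any group at this position moves the number remains open, for example an amine, a methoxy group or a carboxylic acid in place of the chloro.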